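This account rests on a few compounds, and the source may have more. Where it says the series, first, only, none or still open, it means among the compounds named here.

Measured compounds:
- compound 1 `Cc1nn(-c2ncnc3nc[nH]c23)c2c1C(OCc1ccc(C(C)C)cc1)CC(=O)N2`: 5 nM
- compound 2 `C=CCN1c2c(n(C)c(=O)n(C)c2=O)NC1N/N=C/c1ccc(O)cc1O`: 340 nM
- compound 3 `Cc1nn(-c2ncnc3nc[nH]c23)c2c1C(OCc1ccccc1F)CC(=O)N2`: 4 nM

All three were run in a functional assay on HEK293 cells for agonist activity at G-protein coupled receptor 39 (Homo sapiens), read by scintillation proximity assay and inositol phosphate accumulation, with a stated time of 75 min, in the presence of a further agent that is not named here; on this read-out lower numbers stand for an effect already at smaller amounts and higher numbers for an effect only at larger amounts of compound. Among the measured compounds shown here, compound 1 gives 5 nM and sits second highest of the three numbers, with compound 3 at 4 nM nearest and within the scatter, and compound 2 at 340 nM furthest, on a different core, so no single step links it to compound 1.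

Compound 4 `Cc1nn(-c2ncnc3nc[nH]c23)c2c1C(OCc1ccc(C#N)cc1)CC(=O)N2` is not yet measured. It differs from compound 1 as follows: cyano in place of isopropyl on an aromatic carbon. For the measured compounds named here, the one measured step on the shared core, a 1.3-fold lower number from compound 1 to compound 3 (0.10 log units; within the scatter), exchanged the group on the benzyl portion and left the number within the scatter. Going by the values given here, that step bears on the present change only loosely, since it moves a different group to a different place, and no measured pair shows cyano entering. The expectation is therefore a step of about a 1.4-fold higher number from compound 1 to compound 4 (0.15 log units; within the scatter) in this assay, with no direction firmly indicated. Compound 4 is estimated at 7 nM, in the range 2.5 nM to 25 nM.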

Compound 4, half-maximal effective concentration: 4 nM
Beside the measured number, compound 4's estimate is 1.8-fold (0.24 log units) above it; low and high end bracket the measured number.
By their numbers in this assay, from the lowest: compounds 3, 4 and 1 (each within the scatter of the next); then compound 2.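

In this assay, cyano in place of isopropyl on the aromatic carbon para to a large group gives a 1.3-fold lower number from compound 1 to compound 4 (0.10 log units; within the scatter), so a hydrogen-bond acceptor can enter at this position, and isopropyl with its 3 carbon atoms can leave, without the number moving beyond the scatter. The other new step, no change at the digits printed from compound 3 to compound 4 (within the scatter), shows that 4-cyanophenyl and 2-fluorophenyl cannot be told apart here either, so all three compounds on the shared core now lie within the scatter of one another. Nothing available explains why these changes leave the number in place.

Among the compounds shown here, no step on the shared core yet goes beyond the scatter, so it remains open which change at this position would shift the number. A primary amine, a carboxylic acid or a longer alkyl chain on that aromatic carbon would test this.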